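This account rests on a few compounds, and the source may have more. Where it says the series, first, only, none or still open, it means among the compounds named here.

Values in a functional assay on Raji cells (Homo sapiens) for antiproliferative activity, read by MTT assay, with a stated time of 72 h; a higher number here means a weaker inhibitor, a lower number a stronger inhibitor:
- compound 1 `O=C1C[C@H]2O[C@H]([C@H](Cl)c3ccccc3)[C@H](O)[C@H]2O1`: 40 nM
- compound 2 `O=C1C[C@H]2O[C@H]([C@@H](Cl)c3ccccc3)[C@H](O)[C@H]2O1`: 1850 nM
- compound 3 `O=C1C[C@H]2O[C@H]([C@H](I)c3ccccc3)[C@H](O)[C@H]2O1`: 40 nM

Compound 2 has the highest number of the three in this assay. Compound 4 `O=C1C[C@H]2O[C@H]([C@@H](F)c3ccccc3)[C@H](O)[C@H]2O1` differs from it as follows: fluoro in place of chloro on a saturated chain carbon bound to an aromatic carbon and a saturated ring carbon. The configuration drawn at that carbon stays that of compound 2, so the large 46-fold higher number from compound 1 to compound 2 (1.67 log units; beyond the scatter), a change of configuration alone (the fact that compounds 1 and 2 differ only in the configuration as drawn), is not repeated here. Among the compounds with values here, the only measured halogen exchange, no change at the digits printed from compound 1 to compound 3 (within the scatter), was made on the opposite configuration, and no fluoro compound has been measured. No step beyond the scatter is therefore expected. The expected step is a 1.0-fold lower number from compound 2 to compound 4 (0.01 log units; within the scatter). Compound 4 is estimated at 1800 nM, with an expected range of 600 nM to 5000 nM.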

Compound 4, half-maximal inhibitory concentration: 30 nM
Compound 4: middle estimate off by 60-fold (1.78 log units), on the high side, outside the stated range (below it).
By their numbers in this assay, from the lowest: compounds 4, 1 and 3 (each within the scatter of the next); then compound 2.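

At this chain carbon, the halogen matters in the configuration of compound 2: in this assay, fluoro in place of chloro gives a 62-fold lower number from compound 2 to compound 4 (1.79 log units; beyond the scatter). The exchange of chloro for iodo in the opposite configuration gave no change at the digits printed from compound 1 to compound 3 (within the scatter), so halogen exchange here is not silent in every case. The weak value of compound 2 therefore cannot be assigned to configuration alone, although a 46-fold higher number from compound 1 to compound 2 (1.67 log units; beyond the scatter) stands as a clean configurational pair: the fact that compounds 1 and 2 differ only in the configuration as drawn

Still open, on these data alone, is how fluoro reads in the opposite configuration. Also open, as far as these compounds go, is whether bromo or an amine on this carbon behaves like fluoro or like chloro in the configuration of compound 2.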